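The source may hold more compounds than are shown below. What is called first, only, known or untested is meant among the compounds shown, and "the series" means these compounds.

Working notes on the series.

Two compounds have so far been run in a functional assay for inhibition, with Homo sapiens as the target; on this read-out lower numbers stand for stronger inhibition and higher numbers for weaker inhibition. Compound 1 `CCCc1ncn2c(SC)nncc12` gives a result that is a limit of the assay, not a number: in this assay compound 1 reaches only > 48000 nM. Compound 2 `CCCc1nc(C)c2c(C(C)C)cnc(Nc3cc[nH]n3)n12` likewise gives only a limit in this assay, at > 48000 nM. Among the compounds with values here, compound 2 therefore stands at the same limit as the one other value shown (the limit of > 48000 nM in this assay, at which 2 of the 2 values shown sit); neither value is a measured number, so no step between compound 1 and compound 2 can be computed and no ordering between them is claimed.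

Compound 3 `CCCc1cnc(Nc2cc[nH]n2)n2c(CCC)nc(C)c12` is yet to be measured in this assay. It has the same atoms as compound 2, joined differently: propyl in place of isopropyl on an aromatic carbon. Within the data shown here, both measured values sit at the limit, so there is no measured step on which a direction could rest. The expectation for the step from compound 2 to compound 3 is therefore none beyond the scatter, a step that the limit leaves unreadable from compound 2 to compound 3, with compound 3 most likely again reported only as a limit. The estimate for compound 3 in this assay is 60000 nM, expected to lie between 20000 nM and 200000 nM.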

Compound 3, half-maximal inhibitory concentration: > 48000 nM
Compound 3: only a limit was reported (the forecaster's own chance of this, stated with the estimate: 80%); the middle value is on the limit's open side.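

Compound 3 is again only a limit in this assay, at > 48000 nM. Compound 2 is also a limit, so the step from propyl in place of isopropyl cannot be read between compound 2 and compound 3: the limit of > 48000 nM in this assay, at which 3 of the 3 values shown sit.

The compounds shown leave open whether any of these structures has a measurable inhibitory concentration in this assay.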